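Adding a third methoxy group to a chalcone-type pyrazole

A few compounds are considered here, and "the series" means these few. Any claim that something is new, unique, unknown or untested is made for them only; others in the source may bear on it.

Compound 1 `COc1ccc(-c2cc(/C=C/C(=O)c3ccc(N)cc3)[nH]n2)cc1` and compound 3 `COc1ccc(-c2cc(/C=C/C(=O)c3ccc(N)cc3)[nH]n2)cc1OC` share one core, while compound 2 `COc1ccc(C(=O)/C=C/c2cc(-c3cc(OC)c(OC)c(OC)c3)n[nH]2)cc1OC` has a different one; the difference between the two cores is not broken down here. In a functional assay on KM12 cells (Homo sapiens) for inhibition, read by sulforhodamine B assay, with a stated time of 48 h (on this read-out higher numbers stand for weaker inhibition of growth and lower numbers for stronger inhibition of growth), compound 1 gives 1540 nM, compound 3 gives 1680 nM, and compound 2 gives 1070 nM. All three numbers lie within the usual scatter of one another, so no order among them can be read.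

The change from compound 1 to compound 3 is methoxy in place of hydrogen on an aromatic carbon, and it produced a 1.1-fold higher number from compound 1 to compound 3 (0.04 log units; within the scatter).

Compound 4 `COc1cc(C(=O)/C=C/c2cc(-c3cc(OC)c(OC)c(OC)c3)n[nH]2)cc(OC)c1OC` has not yet been measured in this assay. It stands to compound 2 as compound 3 stands to compound 1: the change is methoxy in place of hydrogen on an aromatic carbon. The surroundings are not identical, since here the place is also meta to a methoxy group, so this is the same kind of change rather than the same change. Among the measured compounds shown here, the one measured example of this kind, the step from compound 1 to compound 3, left the number essentially where it was, and the expectation for compound 4 rests on that single precedent applied to compound 2, whose number is 1070 nM. Compound 4 is therefore expected to show a 1.1-fold higher number from compound 2 to compound 4 (0.05 log units; within the scatter), with an estimated value of 1200 nM, most likely between 500 nM and 3000 nM.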

Compound 4, concentration for 50% growth inhibition: 1490 nM
The estimate for compound 4 lay 1.2-fold (0.09 log units) below the measured number; the range from low to high includes it.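

In this assay, methoxy in place of hydrogen on an aromatic carbon gave a 1.4-fold higher number from compound 2 to compound 4 (0.14 log units; within the scatter), so on the core of compound 2 this change left no measurable mark on the number. Set beside the earlier step on the other core, the same kind of change reads alike on both cores: the same change on two cores in this assay, a 1.1-fold higher number (0.04 log units; within the scatter) from compound 1 to compound 3 and a 1.4-fold higher number (0.14 log units; within the scatter) from compound 2 to compound 4, 1.3-fold (0.11 log units) apart, within the scatter of two such steps This shows that, in these two pairs, the change carried from one core to the other without any detectable shift in growth inhibition; it does not show that the change is without effect, as a small real step could lie hidden within the scatter, and two pairs with different surroundings cannot establish a rule for the series.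

The compounds shown leave open whether a different group on the same aromatic carbon, such as a hydroxyl, a chlorine or an ethoxy, would move the number beyond the scatter. They also leave open how the two cores compare directly, as compound 2 and compound 4 differ from compound 1 and compound 3 in more than one place, so the contribution of the amino group cannot be separated from the rest.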